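Restoring the fluoro group on compound 3

A few compounds are considered here, and "the series" means these few. Any claim that something is new, unique, unknown or untested is made for them only; others in the source may bear on it.

Measured in a functional assay on PC-3 cells (Homo sapiens) for inhibition, read by MTT assay, with a stated time of 48 h, tested at 10 uM; on this read-out lower numbers stand for less inhibition of growth and higher numbers for more inhibition of growth at the one concentration tested:
- compound 1 `Cc1oc2c([C@H]3CCN(C)C[C@H]3O)c(O)cc(O)c2c(=O)c1C(O)c1ccc(F)c(Br)c1`: 72%
- compound 2 `Cc1oc2c([C@H]3CCN(C)C[C@H]3O)c(O)cc(O)c2c(=O)c1C(O)c1c(Cl)cccc1Cl`: 0%
- compound 3 `COc1ccc(C(O)c2c(C)oc3c([C@H]4CCN(C)C[C@H]4O)c(O)cc(O)c3c2=O)cc1Br`: 0%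

Compound 3 stands level with compound 2, together the lowest of the three and far under compound 1. Compound 4 `Cc1oc2c([C@H]3CCN(C)C[C@H]3O)c(O)cc(O)c2c(=O)c1C(O)c1ccc(F)cc1` carries 4-fluorophenyl in place of 3-bromo-4-methoxyphenyl on a saturated chain carbon bound to an aromatic carbon and an oxygen on a saturated carbon. The closest evidence is a number 72 percentage points lower from compound 1 to compound 3 (beyond the scatter), a large step on methoxy in place of fluoro. The step of no change at the digits printed from compound 2 to compound 3 (within the scatter) offers no guidance, and a number 72 percentage points lower from compound 1 to compound 2 (beyond the scatter) was also large. Among the compounds with values here, no measured compound shows the fluoro group without the bromine, so only part of that large step is expected to return. The expected rise is a number 35 percentage points higher from compound 3 to compound 4 (beyond the scatter). For compound 4 the estimate is 35%, with an expected range of 5% to 70%.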

Compound 4, percent growth inhibition at one concentration: 0%
Compound 4: middle estimate off by 35 percentage points, on the high side; the whole stated range lies above it.
By their numbers in this assay, from the lowest: compounds 2, 3 and 4 (each within the scatter of the next); then compound 1.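

Hydrogen in place of bromo on an aromatic carbon gives a number 72 percentage points lower from compound 1 to compound 4 (beyond the scatter) and so the fluoro group without the bromine does not keep the growth inhibition of compound 1. The change on the saturated chain carbon gives no change at the digits printed from compound 3 to compound 4 (within the scatter) and no change at the digits printed from compound 2 to compound 4 (within the scatter) so 4-fluorophenyl sits with the two other aryl groups that lack the activity, leaving only the 3-bromo-4-fluorophenyl of compound 1 apart from them. Nothing at hand gives a reason for this.

Going by these compounds, whether the bromine alone would hold the activity stays open. So does the effect of an amine or a carboxylic acid in place of the bromo group.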